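The compounds below may be only part of what the source reports. "The series", "measured", "known", "first", "only" and "open" are said of these compounds alone.

Compound 1, `COc1ccc(S(=O)(=O)/C(=C/c2ccc(C)s2)C(=O)c2ccc(Cl)cc2)cc1`, and compound 2, `Cc1ccc(S(=O)(=O)/C(=C/c2ccc(C)s2)C(=O)c2ccc(Cl)cc2)cc1`, share one core, while compound 3, `COc1ccc(S(=O)(=O)/C(=C/c2ccc(Br)cc2)C(=O)c2ccc(Br)cc2)cc1`, and compound 4, `Cc1ccc(S(=O)(=O)/C(=C/c2ccc(Br)cc2)C(=O)c2ccc(Br)cc2)cc1`, share another; the difference between the two cores is not broken down here. In a functional assay on DU-145 cells (Homo sapiens) for inhibition, read by trypan blue exclusion, with a stated time of 96 h (on this read-out lower numbers stand for stronger inhibition of growth and higher numbers for weaker inhibition of growth), compound 1 gives 25000 nM, and compound 2 gives 50000 nM. The change from compound 1 to compound 2 is methyl in place of methoxy on an aromatic carbon, and it made a 2.0-fold higher number from compound 1 to compound 2 (0.30 log units; within the scatter). Within the data shown here, compound 3 gives 6000 nM in this assay, the lowest of the three numbers measured so far. The change from compound 3 to compound 4 is methyl in place of methoxy on an aromatic carbon, the same change as between compound 1 and compound 2, at the same kind of place. Because the earlier step was a 2.0-fold higher number from compound 1 to compound 2 (0.30 log units; within the scatter), the step from compound 3 to compound 4 is expected to be about as small, around a 1.7-fold higher number from compound 3 to compound 4 (0.22 log units; within the scatter). Compound 4 is therefore estimated at 10000 nM in this assay, most likely between 4000 nM and 25000 nM, with the measurement still to come.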

Compound 4, concentration for 50% growth inhibition: 10000 nM
Compound 4: the middle estimate sits on the measured number at the digits printed; low and high end bracket the measured number.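

In this assay, the newly measured pair gave a 1.7-fold higher number from compound 3 to compound 4 (0.22 log units; within the scatter), so this step is small as well. Set beside the same swap on the other core, the two steps agree: the same change on two cores in this assay, a 2.0-fold higher number (0.30 log units; within the scatter) from compound 1 to compound 2 and a 1.7-fold higher number (0.22 log units; within the scatter) from compound 3 to compound 4, 1.2-fold (0.08 log units) apart, within the scatter of two such steps. On these two cores, then, going from 4-methoxyphenyl to 4-methylphenyl moves the number by no more than repeated measurements of a single compound might, and the size of the step carries over; this does not show that the step would stay as small on a further core, and with both steps within the scatter, neither group can be called better than the other.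

The compounds shown carry only methoxy and methyl at this place, so it stays open what an amine, a carboxylic acid or a longer chain such as butoxy would do there. As far as these compounds go, whether the step stays this small in other cells or in other kinds of assay also remains open.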